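Diethylamino to 4-methylpiperidin-1-yl on compound 2

The source may hold more compounds than are shown below. What is called first, only, known or untested is meant among the compounds shown, and "the series" means these compounds.

Compound 1 `CC1CCN(Cc2ccc3nc(NC(=O)N/N=C/c4cn(Cc5cccc(Cl)c5)c5ccccc45)sc3c2)CC1`: 2810 nM
Compound 2 `CCN(CC)Cc1ccc2nc(NC(=O)N/N=C/c3cn(Cc4ccc(C)cc4)c4ccccc34)sc2c1`: 1510 nM

In a functional assay on A549 cells (Homo sapiens) for cytotoxicity, read by MTT assay, with a stated time of 72 h (a lower number here means a stronger inhibitor, a higher number a weaker inhibitor), compound 2 gives 1510 nM and lies within the scatter of compound 1 at 2810 nM so the two cannot be ranked. Among the compounds with values here, compound 3 `Cc1ccc(Cn2cc(/C=N/NC(=O)Nc3nc4ccc(CN5CCC(C)CC5)cc4s3)c3ccccc32)cc1` differs from compound 2 in one place only: 4-methylpiperidin-1-yl in place of diethylamino on a saturated chain carbon bound to an aromatic carbon and no measured pair isolates this change. Compound 1 carries the same 4-methylpiperidin-1-yl and gives 2810 nM on a different core, so no step beyond the scatter is expected. The estimated step is a 1.3-fold higher number from compound 2 to compound 3 (0.12 log units; within the scatter) and is expected to stay small. For compound 3 the expected value is 2000 nM with an estimated range from 850 nM to 4700 nM as its bounds.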

Compound 3, half-maximal inhibitory concentration: 2180 nM
Estimate against measurement, compound 3: 1.1-fold (0.04 log units) below; low and high end bracket the measured number.
By their numbers in this assay, from the lowest: compounds 2, 3 and 1 (each within the scatter of the next).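

In this assay the swap of diethylamino for 4-methylpiperidin-1-yl on a saturated chain carbon bound to an aromatic carbon now has a measured pair, with a 1.4-fold higher number from compound 2 to compound 3 (0.16 log units; within the scatter) and so within the scatter. The swap of 3-chlorophenyl for 4-methylphenyl on a saturated chain carbon bound to an aromatic nitrogen also has one, with a 1.3-fold lower number from compound 1 to compound 3 (0.11 log units; within the scatter) and likewise within the scatter. Neither group can be ranked against the one it replaces. On these data alone, whether morpholin-4-yl or a carboxylic acid at the first place would give a step beyond the scatter stays open. Nothing at hand explains these numbers.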